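Swapping Phenyl for Methoxy on a Biaryl Alcohol

The source may report more compounds than this note shows. Statements on the series, on what has been measured and on what is new or still open speak of the compounds shown alone.

Compound 1 `CC(C)c1cc(C(C)(C)C)cc(-c2ccccc2-c2ccccc2)c1CO` and compound 2 `COc1ccccc1-c1cc(C(C)(C)C)cc(C(C)C)c1CO` differ in one place: methoxy in place of phenyl on an aromatic carbon. In a functional assay on RKE cells for antagonist activity at Vasoactive intestinal polypeptide receptor 1 (Rattus norvegicus), read by HTRF and cAMP accumulation, with stated times of 10 min and 30 min (on this read-out higher numbers stand for weaker inhibition and lower numbers for stronger inhibition), compound 1 gives 3200 nM, while compound 2 gives 820 nM, the change making a 3.9-fold lower number from compound 1 to compound 2 (0.59 log units; beyond the scatter). Compound 3 `CC(C)c1cc(C(C)(C)C)cc(-c2cccc(-c3ccccc3)c2)c1CO` has the same atoms as compound 1 joined differently; how the two cores differ is not broken down here. In this assay compound 3 gives 210 nM, the lowest of the three numbers. Compound 4 `COc1cccc(-c2cc(C(C)(C)C)cc(C(C)C)c2CO)c1` is not yet measured and differs from compound 3 by methoxy in place of phenyl on an aromatic carbon. This is the same kind of change as from compound 1 to compound 2, but the place differs: there the methoxy sits ortho to a large group, here meta to a large group. For compound 4 a step in the same direction is expected, a 2.1-fold lower number from compound 3 to compound 4 (0.32 log units; beyond the scatter), because the earlier change gave a 3.9-fold lower number from compound 1 to compound 2 (0.59 log units; beyond the scatter), though the different place lowers confidence. Compound 4 is therefore estimated at 100 nM in this assay, between 30 nM and 600 nM.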

Compound 4, half-maximal inhibitory concentration: 200 nM
Beside the measured number, compound 4's estimate is 2.0-fold (0.30 log units) below it; the measured number falls inside the stated range.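

In this assay, methoxy in place of phenyl on an aromatic carbon gives a 1.1-fold lower number from compound 3 to compound 4 (0.02 log units; within the scatter), so on the core of compound 3 the two groups cannot be told apart. The change therefore does not carry across these two cores with the same size: the same change on two cores in this assay, a 3.9-fold lower number (0.59 log units; beyond the scatter) from compound 1 to compound 2 and a 1.1-fold lower number (0.02 log units; within the scatter) from compound 3 to compound 4, 3.7-fold (0.57 log units) apart, beyond the scatter of two such steps The two pairs differ both in the core and in the place of the group, and they do not show which of these accounts for the gap.

The compounds shown leave open how an amine or a carboxylic acid would compare with phenyl and methoxy at the place meta to a large group. They also leave open whether a longer chain, such as ethoxy, would behave as methoxy does on either core.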